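A few compounds are considered here, and "the series" means these few. Any claim that something is new, unique, unknown or untested is made for them only; others in the source may bear on it.

Measured so far in a functional assay on the whole organism for inhibition of sodium-dependent dopamine transporter (Mus musculus); on this read-out lower numbers stand for an effect already at smaller amounts and higher numbers for an effect only at larger amounts of compound:
- compound 1 `CC(C)NCC(=O)Nc1cccc2c1CN(C)CC2c1ccccc1`: about 30 mg/kg
- compound 2 `CCCCNCC(=O)Nc1cccc2c1CN(C)CC2c1ccccc1`: 25 mg/kg
- compound 3 `CC(C)NCCC(=O)Nc1cccc2c1CN(C)CC2c1ccccc1`: about 200 mg/kg

Compound 3 stands at the highest number of the three in this assay: the step of a 6.7-fold higher number from compound 1 to compound 3 (0.82 log units; beyond the scatter) and the step of an 8.0-fold higher number from compound 2 to compound 3 (0.90 log units; beyond the scatter) both lie beyond the scatter, whereas the step of a 1.2-fold lower number from compound 1 to compound 2 (0.08 log units; within the scatter) is within it. Compound 4 `CN1Cc2c(NC(=O)CN3CCCC3)cccc2C(c2ccccc2)C1` differs from compound 3 by pyrrolidin-1-yl in place of (isopropylamino)methyl on a saturated chain carbon bound to a carbonyl carbon. Read one bond further out, this change takes the chain back to the length found in compound 1 and compound 2, and the two steps that added a chain carbon, from compound 1 and from compound 2 to compound 3, each raised the number by a modest but clear amount. Step a 1.2-fold lower number from compound 1 to compound 2 (0.08 log units; within the scatter) suggests that the substituent on the amine nitrogen matters little. Among the compounds with values here, no measured pair tells how a pyrrolidin-1-yl group compares with a secondary amine. Compound 4 is therefore expected to return toward the numbers of compound 1 and compound 2, a step of about a 6.7-fold lower number from compound 3 to compound 4 (0.82 log units; beyond the scatter), with an estimate of 30 mg/kg and a range from 10 mg/kg to 100 mg/kg in this assay.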

Compound 4, dose for half-maximal effect: 45 mg/kg
Estimate against measurement, compound 4: 1.5-fold (0.18 log units) below, and the stated range covers the measured number.
By their numbers in this assay, from the lowest: compounds 2, 1 and 4 (each within the scatter of the next); then compound 3.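

In this assay, exchanging 2-(isopropylamino)ethyl for (pyrrolidin-1-yl)methyl on the carbonyl carbon gives a 4.4-fold lower number from compound 3 to compound 4 (0.65 log units; beyond the scatter) and so recovers most of what the longer chain had cost. The earlier compounds shown here carried only open-chain secondary amines at this position, and compound 4 now shows that the amine nitrogen can sit in a ring, with no hydrogen-bond donor counted on the group, without a step beyond the scatter: the steps are a 1.5-fold higher number from compound 1 to compound 4 (0.18 log units; within the scatter) and a 1.8-fold higher number from compound 2 to compound 4 (0.26 log units; within the scatter) in this assay. Nothing available explains these numbers.

The compounds shown leave open whether a piperidine or a morpholine ring would fit this position as well as pyrrolidin-1-yl does. They also leave open how 2-(pyrrolidin-1-yl)ethyl, the ring on the longer chain, would compare with compound 3.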